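A few compounds are considered here, and "the series" means these few. Any claim that something is new, unique, unknown or untested is made for them only; others in the source may bear on it.

Measured so far:
compound 1 `NC(=O)N1CCN(C(=S)SCc2cn(Cc3ccc(F)cc3)nn2)CC1` gives 62700 nM
compound 2 `O=C(NC1CCCCC1)N1CCN(C(=S)SCc2cn(Cc3ccc(F)cc3)nn2)CC1` gives > 128000 nM

Of the compounds shown here, two have been tested in a functional assay on EC9706 cells (Homo sapiens) for cytotoxicity, read by MTT assay, with a stated time of 72 h; a higher number here means a weaker inhibitor, a lower number a stronger inhibitor. Going by the values given here, compound 1 `NC(=O)N1CCN(C(=S)SCc2cn(Cc3ccc(F)cc3)nn2)CC1` gives 62700 nM there, the only outright number in the set. Compound 2 `O=C(NC1CCCCC1)N1CCN(C(=S)SCc2cn(Cc3ccc(F)cc3)nn2)CC1` gives only a limit of the assay, > 128000 nM, which is the limit of > 128000 nM in this assay, at which 1 of the 2 values shown sits. The step of an at least 2.0-fold higher number from compound 1 to compound 2 (0.30 log units; that floor lies within the scatter) therefore rests on a floor that lies within the scatter, and it leaves open whether cyclohexyl on the amide-type nitrogen changes potency at all.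

Compound 3 `Cc1ccc(Cn2cc(CSC(=S)N3CCN(C(N)=O)CC3)nn2)cc1` has not been measured. It differs from compound 1 by methyl in place of fluoro on an aromatic carbon, so that 4-fluorobenzyl becomes 4-methylbenzyl. Among the compounds with values here, neither measured compound varies at this position; the one measured step sits on the amide-type nitrogen and is itself within the scatter. Within the data shown here, no measured step bears on this change, so no step beyond the scatter in this assay is expected. Compound 3 is estimated at 62700 nM, with a range from 25000 nM to 160000 nM. That estimate means an expected step of no change at the digits printed from compound 1 to compound 3 (within the scatter), within the scatter.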

Compound 3, half-maximal inhibitory concentration: > 128000 nM
Compound 3 ended at the assay's limit; the forecaster's own chance of this, stated with the estimate: 25%; at least 2.0-fold (0.30 log units) between middle value and limit.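

In this assay compound 3 gives > 128000 nM, which is a limit of the assay and not a number. As far as these compounds go, replacing 4-fluorobenzyl with 4-methylbenzyl gives an at least 2.0-fold higher number from compound 1 to compound 3 (0.30 log units; that floor lies within the scatter), so this position now has a reading of its own, but the true size of the change remains unknown and the floor alone does not establish that the methyl compound is weaker. Compound 1 remains the only compound with an outright number, and each of the two single changes made to it, one on the amide-type nitrogen and one on the aromatic ring, ends at the same limit: the limit of > 128000 nM in this assay, at which 2 of the 3 values shown sit.

The compounds shown leave open how far past the limit compound 3 lies, and therefore whether the fluoro group matters for this cytotoxicity or the difference is no larger than ordinary repeat variation. They also leave open whether other groups on this aromatic carbon, such as a plain hydrogen, a chlorine, a methoxy group or an amine, would give an outright number that could be compared directly with compound 1.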